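Swapping one five-membered ring for another on the shared core

The source may hold more compounds than are shown below. What is called first, only, known or untested is meant among the compounds shown, and "the series" means these compounds.

Of the compounds shown here, three built on the same core have been measured in a functional assay on A2780 cells (Homo sapiens) for inhibition; a higher number here means a weaker inhibitor, a lower number a stronger inhibitor. Compound 1 `CC(C(=O)Nc1cc(C2CC2)[nH]n1)c1ccc(-n2ccnc2O)cc1` gives 6980 nM, the highest of the three numbers. Compound 2 `CC(C(=O)Nc1cc(C2CC2)[nH]n1)c1ccc(N2Cc3ccccc3C2=O)cc1` gives 4750 nM, a number that lies within the usual scatter of compound 1, so the two cannot be told apart. Compound 3 `C[C@H](C(=O)Nc1cc(C2CC2)[nH]n1)c1ccc(N2CCCC2)cc1` gives 220 nM, which is far lower than compound 1 and well beyond the scatter, marking it as the strongest inhibitor among the three.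

Compound 4 `CC(C(=O)Nc1cc(C2CC2)[nH]n1)c1ccc(N2CC(=O)NC2=O)cc1` has not yet been measured in this assay. It differs from compound 1 in a single place: a group of 7 heavy atoms (3 carbon, 2 nitrogen, 2 oxygen; one five-membered non-aromatic ring with 2 hetero atoms) in place of a group of 6 heavy atoms (3 carbon, 2 nitrogen, 1 oxygen; one five-membered aromatic ring with 2 hetero atoms), on an aromatic carbon. The group that leaves and the group that enters are of nearly the same size, both carry one hydrogen-bond donor, and both sit on an aromatic carbon para to a large group.

For the measured compounds named here, no measured pair shows a step of this kind, so there is nothing to lean on beyond the closeness of the two groups. The step is expected to be small, with no clear direction beyond the scatter, giving a 1.0-fold higher number from compound 1 to compound 4 (0.00 log units; within the scatter). Compound 4 is estimated to reach 7000 nM, with a range from 2500 nM to 20000 nM.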

Compound 4, half-maximal inhibitory concentration: 4540 nM
Compound 4: the middle estimate sits 1.5-fold (0.19 log units) above what was measured; the range from low to high includes it.
By their numbers in this assay, from the lowest: compound 3; then compounds 4, 2 and 1 (each within the scatter of the next).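

In this assay, replacing the five-membered aromatic ring of compound 1 with the 2,4-dioxoimidazolidin-1-yl group gives a 1.5-fold lower number from compound 1 to compound 4 (0.19 log units; within the scatter) and so produces no readable change. For the compounds shown here, this is the first direct comparison at this position, on an aromatic carbon para to a large group, since no earlier pair of compounds differed in only one place. It shows that, at least for these two groups, a non-aromatic five-membered ring with two double bonds outside aromatic rings and an aromatic five-membered ring cannot be told apart in this measurement, even though the two differ in ring type and in their count of hydrogen-bond acceptors. No measurement here explains why the two groups give such similar numbers. From the compounds shown here alone, it remains open whether a pyrrolidin-2-one ring, with only one carbonyl, would also fall within the scatter of compound 4 at this position. Also open, going by these compounds, is how a morpholine ring, a carboxylic acid or a short open chain such as an acetamide on the same aromatic carbon would compare with compound 1.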